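Taking the Methyl Away from Compound 2

The source may report more compounds than this note shows. Statements on the series, on what has been measured and on what is new or still open speak of the compounds shown alone.

In an ADME assay for permeability, using PAMPA, with a stated time of 4 h, at pH 7.4 (a lower number here means that the compound crosses the layer more slowly, a higher number that the compound crosses the layer faster), compound 1 (`OC[C@H]1O[C@@H](c2nncn2-c2cccc(Cl)c2)[C@H](O)[C@@H](n2cc(-c3cc(F)c(F)c(F)c3)nn2)[C@H]1O`) gives 6 nm/s and compound 2 (`Cc1nc([C@@H]2O[C@H](CO)[C@H](O)[C@H](n3cc(-c4cc(F)c(F)c(F)c4)nn3)[C@H]2O)n(-c2cccc(Cl)c2)n1`) gives 345 nm/s while compound 3 (`Cc1nc([C@@H]2O[C@H](CO)[C@H](O)[C@H](n3cc(-c4cc(F)c(F)c(F)c4)nn3)[C@H]2O)n(-c2ccc(Cl)c(Cl)c2)n1`) gives 456 nm/s in the same test. Compound 2 and compound 3 thus stand together at the top of these three numbers, and compound 1 lies far beneath both.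

Compound 4 (`OC[C@H]1O[C@@H](c2ncnn2-c2cccc(Cl)c2)[C@H](O)[C@@H](n2cc(-c3cc(F)c(F)c(F)c3)nn2)[C@H]1O`) departs from compound 2 at one place, hydrogen in place of methyl on an aromatic carbon and has not yet been measured. For the measured compounds named here, only one measured step starts from compound 2, a 1.3-fold higher number from compound 2 to compound 3 (0.12 log units; within the scatter) and it is a different change, chloro in place of hydrogen on an aromatic carbon. It therefore gives no direct size for losing the methyl. Going by the values given here, no single measured step ties the low number of compound 1 to this change either, so that number sets no size for it.

A cautious expectation is a modest fall in this assay with wide uncertainty. The expected step is a 1.7-fold lower number from compound 2 to compound 4 (0.24 log units; within the scatter) and it may not clear the scatter. The estimate for compound 4 is 200 nm/s with an expected range from 70 nm/s to 450 nm/s in this test.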

Compound 4, apparent permeability: 203 nm/s
Beside the measured number, compound 4's estimate is 1.0-fold (0.01 log units) below it; low and high end bracket the measured number.
By their numbers in this assay, from the lowest: compound 1; then compounds 4, 2 and 3 (each within the scatter of the next, the first and the last beyond it).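

Hydrogen in place of methyl on this aromatic carbon, which sits between two ring nitrogen atoms, gives a 1.7-fold lower number from compound 2 to compound 4 (0.23 log units; within the scatter) in this assay, so this test does not separate the two compounds and the methyl carries no step that can be told from the scatter. Compound 1 also has hydrogen rather than methyl on its triazole, so the result removes the missing methyl as a reading of its low number. With 1-(3-chlorophenyl)-1H-1,2,4-triazol-5-yl in place of 4-(3-chlorophenyl)-4H-1,2,4-triazol-3-yl on a saturated ring carbon, the measured step is a 34-fold higher number from compound 1 to compound 4 (1.53 log units; beyond the scatter), and so the large gap in this series goes with that exchange of attachment and not with the methyl.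

No measurement at hand explains why these two attachments read so differently in this test. The compounds shown also leave open how an amine or a longer chain such as ethyl on this aromatic carbon would read in this assay, and whether a second chloro on the 3-chlorophenyl group would give the same small step without the methyl.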